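This account rests on a few compounds, and the source may have more. Where it says the series, first, only, none or still open, it means among the compounds named here.

Compound 1 `CC1=CC[C@H](C(=O)N(c2cc(C#CC(C)(C)C)sc2C(=O)O)[C@H]2CC[C@](O)(CO[C@H]3CCOC3)CC2)CC1` has been run in an ADME assay on MT4 cells (Homo sapiens) for cytotoxicity, with a stated time of 5 days; on this read-out lower numbers stand for higher toxicity in this test and higher numbers for lower toxicity in this test. In that test compound 1 returns only a limit of the assay, > 20000 nM. Compound 2 `CC(C)(C)C#Cc1cc(N(C(=O)[C@H]2CC[C@H](C)CC2)[C@H]2CC[C@H](OC3CCOC3)CC2)c(C(=O)O)s1` belongs to the same series. In this assay compound 2 likewise returns a limit rather than a number, > 20000 nM. Among the measured compounds shown here, compound 1 therefore stands at the limit of > 20000 nM in this assay, at which 2 of the 2 values shown sit; no pair of measured compounds differing in a single place exists, and the two values show nothing beyond the shared limit. Compound 3 `CC(C)(C)C#Cc1cc(N(C(=O)[C@H]2CC[C@H](C)CC2)[C@H]2CC[C@](O)(CO[C@H]3CCOC3)CC2)c(C(=O)O)s1` is not yet measured in this assay. It differs from compound 1 as follows: 4-methylcyclohexyl in place of 4-methylcyclohex-3-en-1-yl on a carbonyl carbon. From this change no step beyond the scatter is expected in this assay, and the step estimated a step that the limit leaves unreadable from compound 1 to compound 3 is taken as none. Compound 3 is expected to read 22000 nM, within 10000 nM to 50000 nM, most likely again as a limit, because compound 1 already sits at the limit of > 20000 nM in this assay, at which 2 of the 2 values shown sit.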

Compound 3, half-maximal cytotoxic concentration: > 20000 nM
Compound 3 was reported as a limit (the forecaster's own chance of this, stated with the estimate: 85%); the middle value does not contradict the limit.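

No step can be read from compound 1 to compound 3 in this assay, because both are reported only as limits: the limit of > 20000 nM in this assay, at which 3 of the 3 values shown sit. The compounds shown leave open whether 4-methylcyclohexyl and 4-methylcyclohex-3-en-1-yl on a carbonyl carbon differ at all in this read-out, and where any of the three compounds would give an actual number.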